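Replacing a Ring with a Fluorophenylsulfonyl Chain

A few compounds are considered here, and "the series" means these few. Any claim that something is new, unique, unknown or untested is made for them only; others in the source may bear on it.

Compound 1 `COc1cccc(-c2nc3sccn3c2-c2ccnc(NCCCNS(=O)(=O)c3ccc(F)cc3)n2)c1` and compound 2 `CN1CCCN(CCNc2nccc(-c3c(-c4cccc(O)c4)nc4sccn34)n2)S1(=O)=O` share a core. In a functional assay on cells (Panel melanoma (Carcinoma cell lines), Homo sapiens) for inhibition, read by sulforhodamine B assay, with a stated time of 48 h, tested at 10 uM (on this read-out higher numbers stand for more inhibition at the one concentration tested (going by the name of the read-out) and lower numbers for less inhibition), compound 1 gives 101%, while compound 2 gives 84.8%, the lower of the two numbers and beyond the scatter from compound 1. Compound 3 `O=S(=O)(NCCCNc1nccc(-c2c(-c3cccc(O)c3)nc3sccn23)n1)c1cccc(F)c1` differs from compound 2 by a group of 12 heavy atoms (7 carbon, 1 nitrogen, 2 oxygen, 1 fluorine, 1 sulfur; one six-membered aromatic ring of carbon only) in place of a group of 9 heavy atoms (4 carbon, 2 nitrogen, 2 oxygen, 1 sulfur; one six-membered non-aromatic ring with 3 hetero atoms), on a saturated chain carbon, two bonds along the chain from a nitrogen on an aromatic ring. Among the compounds with values here, no step between measured compounds is at hand, so the expectation leans on compound 1, which also bears a fluorophenylsulfonyl group on a chain and gives 101% in this assay . Compound 3 is expected to rise by a number 10.2 percentage points higher from compound 2 to compound 3 (beyond the scatter). Compound 3 is thus estimated at 95%, between 80% and 105%.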

Compound 3, a percentage reported as inhibition, at one concentration (the size of the read-out at that concentration, not a potency): 101%
Estimate against measurement, compound 3: 6 percentage points below, and the stated range covers the measured number.
By their numbers in this assay, from the lowest: compound 2; then compounds 1 and 3 (each within the scatter of the next).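

At this saturated chain carbon, two bonds along the chain from a nitrogen on an aromatic ring, the change from the six-membered non-aromatic ring with 3 hetero atoms to (((3-fluorophenyl)sulfonyl)amino)methyl gives, in this assay, a number 16.2 percentage points higher from compound 2 to compound 3 (beyond the scatter). This position therefore does not need the non-aromatic ring to keep a high read-out, and the open chain carrying an aromatic ring gives more inhibition. No measurement at hand bears on the reason for this step. On these data alone, the step changes the ring and the chain together, so the share of each remains open. As far as these compounds go, whether an unsubstituted phenylsulfonyl group or a carboxamide in place of the sulfonamide would hold the number also remains open.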